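A few compounds are considered here, and "the series" means these few. Any claim that something is new, unique, unknown or untested is made for them only; others in the source may bear on it.

In a functional assay on a cell-free system (plasma, Oryctolagus cuniculus) for inhibition, with stated times of 5 min, 1 min and 6 min (on this read-out higher numbers stand for weaker inhibition and lower numbers for stronger inhibition), compound 1 `CCOC(=O)c1c(C)nc(-c2cccc(C#N)c2)n1O` gives 17600 nM. Compound 2 `CCOC(=O)c1c(C)nc(-c2cccc(C#N)c2)n1OCC(N)=O` is reported only as a limit of the assay, > 30000 nM. Within the data shown here, compound 3 `CCOC(=O)c1c(C)nc(-c2cccc(C#N)c2)n1OCc1ccccc1Cl` gives 8710 nM, the lowest number so far, and the only step into it from a free hydroxyl-bearing parent is modest: a 2.0-fold lower number from compound 1 to compound 3 (0.31 log units; beyond the scatter). Its margin over the carbamoylmethyl compound is an at least 3.4-fold lower number from compound 2 to compound 3 (0.53 log units; beyond the scatter). The step in the other direction, an at least 1.7-fold higher number from compound 1 to compound 2 (0.23 log units; that floor lies within the scatter), has a floor within the scatter.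

Compound 4 `CCOC(=O)c1c(C)nc(-c2cccc(C#N)c2)n1OCc1ccc([N+](=O)[O-])cc1` keeps the shared core and changes one group of compound 3: 4-nitrophenyl in place of 2-chlorophenyl on a saturated chain carbon bound to an oxygen on an aromatic ring. The same difference can be read as 2-chlorobenzyl to 4-nitrobenzyl. Among the measured compounds shown here, no measured step exchanges one substituted phenyl for another, so the evidence is indirect. The gain seen for compound 3, at 8710 nM, came with a benzyl group, and compound 4 retains a benzyl group, so most of that modest gain is expected to persist. No clear shift beyond the scatter is therefore expected in this assay, with a slight drift upward as the more likely direction. The expected change is a 1.1-fold higher number from compound 3 to compound 4 (0.06 log units; within the scatter). The value for compound 4 is estimated at 10000 nM, with an expected range from 4000 nM to 25000 nM.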

Compound 4, half-maximal inhibitory concentration: 8750 nM
The estimate for compound 4 lay 1.1-fold (0.06 log units) above the measured number, within the range that was stated.
By their numbers in this assay, from the lowest: compounds 3, 4 and 1 (each within the scatter of the next, the first and the last beyond it). At a limit, above all of these: compound 2.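

In this assay, among these compounds, the first exchange of one substituted phenyl for another on a saturated chain carbon bound to an oxygen on an aromatic ring leaves the number unchanged (a 1.0-fold higher number from compound 3 to compound 4 (0.00 log units; within the scatter)), so at this position 2-chlorophenyl and 4-nitrophenyl cannot be told apart. Read from the free hydroxyl of compound 1, the 4-nitrobenzyl group gives a step that stays within the scatter (a 2.0-fold lower number from compound 1 to compound 4 (0.30 log units; within the scatter)), so compound 4 cannot be placed in any order relative to compound 1, even though it cannot be told apart from compound 3 either. The step from the carbamoylmethyl compound (an at least 3.4-fold lower number from compound 2 to compound 4 (0.53 log units; beyond the scatter)) is a floor, since compound 2 is known only as a limit: the limit of > 30000 nM in this assay, at which 1 of the 4 values shown sits.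

Because the exchange alters both the substituent and its place on the ring, the compounds shown cannot say whether either alone would matter, as a 4-chlorobenzyl or 2-nitrobenzyl group would be needed to separate the two. Also open, as far as these compounds go, is whether a phenyl ring bearing an amine or a carboxylic acid, or a longer chain between the oxygen and the phenyl ring, would move the number beyond the scatter.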